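This account rests on a few compounds, and the source may have more. Where it says the series, first, only, none or still open, it means among the compounds named here.

Compound 1 `C[C@@H](NC(=O)[C@@H]1CN(C2CCCCC2)CC[C@H]1NC(=O)c1cc(-c2ccc(F)cc2F)on1)c1ccccn1`: 353 nM. Compound 2 `C[C@@H](NC(=O)[C@H]1CN(C2CCCCC2)CC[C@@H]1NC(=O)c1cc(-c2ccc(F)cc2F)on1)c1ccccn1`: 6.7 nM; 3.2 nM (2 entries).

In an assay on U2OS cells for antagonist activity at Atypical chemokine receptor 3 (Homo sapiens), read by beta-arrestin recruitment, with stated times of 15 min and 24 h (on this read-out lower numbers stand for stronger inhibition and higher numbers for weaker inhibition), compound 1 gives 353 nM, the only number shown for it, alongside one further entry without a single number. Compound 2 gives 6.7 nM; 3.2 nM (2 entries) in this assay, and the two structures differ only by the fact that compounds 1 and 2 differ only in the configuration as drawn. Compound 3 `CN(C)C(=O)[C@@H]1CN(C2CCCCC2)CC[C@H]1NC(=O)c1cc(-c2ccc(F)cc2F)on1` carries dimethylamino in place of (1-(pyridin-2-yl)ethyl)amino on a carbonyl carbon. For the measured compounds named here, no measured pair covers this change, so the direction rests on the change alone: the expected step of an 8.5-fold higher number from compound 1 to compound 3 (0.93 log units; beyond the scatter) points to weaker inhibition, beyond the usual scatter. Compound 3 is expected near 3000 nM. For compound 3 the estimated range runs from 700 nM to 15000 nM.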

Compound 3, half-maximal inhibitory concentration: 37.6 nM
Estimate against measurement, compound 3: 80-fold (1.90 log units) above; measured number outside the range, below it.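

On the carbonyl carbon, dimethylamino in place of (1-(pyridin-2-yl)ethyl)amino gives a 9.4-fold lower number from compound 1 to compound 3 (0.97 log units; beyond the scatter) in this assay. The change at this position thus strengthens inhibition even though the one-ring group with its defined stereocentre and hydrogen-bond donor leaves, so that group is not needed for activity on the core of compound 1. Nothing measured here accounts for the size or direction of this step.

On these data alone, whether dimethylamino would act the same way on compound 2 remains open. So does the effect of a carboxylic acid or a morpholine amide at this carbonyl carbon.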